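Lengthening the Amide Substituent of Compound 1

A few compounds are considered here, and "the series" means these few. Any claim that something is new, unique, unknown or untested is made for them only; others in the source may bear on it.

Of the compounds shown here, two have so far been measured in a functional assay on HT-1080 cells (Homo sapiens) for antiproliferative activity, read by sulforhodamine B assay, with a stated time of 48 h; on this read-out lower numbers stand for stronger inhibition and higher numbers for weaker inhibition. Compound 1 `CCC(=O)Nc1ccc(S(=O)(=O)Oc2ccccc2I)cc1` gives 7200 nM, the highest of the two numbers. Within the data shown here, compound 2 `CC(C)c1ccccc1OS(=O)(=O)c1ccc(NC(=O)CCCCl)cc1` gives 3800 nM, which lies within the scatter of the number for compound 1; the two structures differ in more than one place, so no single step links them. Compound 3 `CCCCCNC(=O)Nc1ccc(S(=O)(=O)Oc2ccccc2I)cc1` is not yet measured. It differs from compound 1 in one place: pentylamino in place of ethyl on a carbonyl carbon. Among the measured compounds shown here, with no measured step to lean on, only a small shift in this assay is expected, of uncertain direction and likely within the scatter. Compound 3 is therefore expected to give about 5000 nM, within 1500 nM to 15000 nM, which amounts to an estimated step of a 1.4-fold lower number from compound 1 to compound 3 (0.16 log units; within the scatter).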

Compound 3, half-maximal inhibitory concentration: 6900 nM
Compound 3: the middle estimate sits 1.4-fold (0.14 log units) below what was measured; measured number inside the range.
By their numbers in this assay, from the lowest: compounds 2, 3 and 1 (each within the scatter of the next).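

In this assay, among these compounds, the first single-place step at this carbonyl carbon, pentylamino in place of ethyl gives a 1.0-fold lower number from compound 1 to compound 3 (0.02 log units; within the scatter). The position therefore takes the pentylcarbamoyl group, with its longer chain and added hydrogen-bond donor, without any separation between the numbers of the two compounds. No available evidence accounts for this result. Going by these compounds, whether a different group on this carbonyl carbon, such as a phenyl ring, a chain ending in a carboxylic acid or one ending in an amine, would separate from compound 1 remains open.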